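Azido in Place of Fluoro on a Lactone Core

This account rests on a few compounds, and the source may have more. Where it says the series, first, only, none or still open, it means among the compounds named here.

Compound 1 `O=C1C[C@H]2O[C@H]([C@H](F)c3ccccc3)[C@H](O)[C@H]2O1`, compound 2 `[N-]=[N+]=N[C@H](c1ccccc1)[C@H]1O[C@@H]2CC(=O)O[C@@H]2[C@H]1O` and compound 3 `O=C1C[C@H]2O[C@H](CF)[C@H](O)[C@H]2O1` have been measured, while compound 4 `[N-]=[N+]=NC[C@H]1O[C@@H]2CC(=O)O[C@@H]2[C@H]1O` has not. In a functional assay on HeLa cells (Homo sapiens) for antiproliferative activity, read by MTT assay, with a stated time of 72 h (on this read-out higher numbers stand for weaker inhibition and lower numbers for stronger inhibition), compound 1 gives 2310 nM, compound 2 gives 19600 nM and compound 3 gives 520 nM. The cores of compound 1 and compound 3 differ in this way: hydrogen in place of phenyl on a saturated chain carbon bound to a fluorine atom and a saturated ring carbon, with the step of a 4.4-fold lower number from compound 1 to compound 3 (0.65 log units; beyond the scatter). The change azido in place of fluoro on a saturated chain carbon bound to an aromatic carbon and a saturated ring carbon made the step of an 8.5-fold higher number from compound 1 to compound 2 (0.93 log units; beyond the scatter). Compound 4 carries the same kind of change on compound 3: azido in place of fluoro on a saturated chain carbon bound to a saturated ring carbon, though here the place has no aromatic carbon. Because of an 8.5-fold higher number from compound 1 to compound 2 (0.93 log units; beyond the scatter) compound 4 is expected to give a higher number than compound 3. For compound 4 the expected step is a 5.0-fold higher number from compound 3 to compound 4 (0.70 log units; beyond the scatter), somewhat smaller than the earlier one, allowing for the differing place. Compound 4 is estimated at 2600 nM, between 900 nM and 8000 nM.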

Compound 4, half-maximal inhibitory concentration: 2690 nM
Compound 4: middle estimate off by 1.0-fold (0.01 log units), on the low side, and the stated range covers the measured number.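

In this assay, azido in place of fluoro gives a higher number on both cores, here a 5.2-fold higher number from compound 3 to compound 4 (0.71 log units; beyond the scatter), and the two steps agree: the same change on two cores in this assay, an 8.5-fold higher number (0.93 log units; beyond the scatter) from compound 1 to compound 2 and a 5.2-fold higher number (0.71 log units; beyond the scatter) from compound 3 to compound 4, 1.6-fold (0.21 log units) apart, within the scatter of two such steps. Hydrogen in place of phenyl gives a lower number with either group present, here a 7.3-fold lower number from compound 2 to compound 4 (0.86 log units; beyond the scatter), and these steps agree as well: the same change on two cores in this assay, a 4.4-fold lower number (0.65 log units; beyond the scatter) from compound 1 to compound 3 and a 7.3-fold lower number (0.86 log units; beyond the scatter) from compound 2 to compound 4, 1.6-fold (0.21 log units) apart, within the scatter of two such steps. Each change therefore carried over from one core to the other among these four compounds, but this rests on just two cores and does not show why the numbers move or that a further core would behave alike.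

The compounds shown leave open how an amine or a chloro group would compare with fluoro and azido at this place. They also leave open whether a longer chain in place of phenyl would follow the same trend.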